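Swapping the chloropyridinylmethyl for benzyl on compound 2

The source may report more compounds than this note shows. Statements on the series, on what has been measured and on what is new or still open speak of the compounds shown alone.

Compound 1 `O=C(N/N=C/c1ccccc1O)c1cc(-c2ccc(Cl)cc2)nn1Cc1ccc(Cl)nc1`: 3680 nM
Compound 2 `COc1ccc(-c2cc(C(=O)N/N=C/c3ccccc3O)n(Cc3ccc(Cl)nc3)n2)cc1`: 8210 nM

In a functional assay on A549 cells (Homo sapiens) for cytotoxicity, read by MTT assay, with a stated time of 96 h (on this read-out lower numbers stand for stronger inhibition and higher numbers for weaker inhibition), compound 2 gives the higher of the two numbers, its nearest neighbour being compound 1, with a 2.2-fold higher number from compound 1 to compound 2 (0.35 log units; beyond the scatter). Compound 3 `COc1ccc(-c2cc(C(=O)N/N=C/c3ccccc3O)n(Cc3ccccc3)n2)cc1` carries phenyl in place of 6-chloropyridin-3-yl on a saturated chain carbon bound to an aromatic nitrogen. No measured step touches this position; the one step shown concerns the aromatic chloro and methoxy and cannot be carried over. With nothing pointing either way, the estimate for compound 3 is a step of a 1.0-fold lower number from compound 2 to compound 3 (0.01 log units; within the scatter), within the scatter. Compound 3 is therefore expected at 8000 nM, in a range from 3000 nM to 22000 nM.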

Compound 3, half-maximal inhibitory concentration: 7690 nM
The estimate for compound 3 lay 1.0-fold (0.02 log units) above the measured number, within the range that was stated.
By their numbers in this assay, from the lowest: compound 1; then compounds 3 and 2 (each within the scatter of the next).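

In this assay benzyl in place of (6-chloropyridin-3-yl)methyl gives a 1.1-fold lower number from compound 2 to compound 3 (0.03 log units; within the scatter) and so no readable change at this position, on a saturated chain carbon bound to an aromatic nitrogen. Among these compounds, this is the first step seen there, and it shows that, with the methoxy compounds, the ring nitrogen and chlorine of the leaving group can go without a change beyond the scatter. Nothing available explains this result.

From the compounds shown here alone, whether the same swap would read alike on compound 1 remains open. So does whether an aminomethyl group or a longer chain in place of benzyl would move the number.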